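The source may hold more compounds than are shown below. What is called first, only, known or untested is meant among the compounds shown, and "the series" means these compounds.

Three compounds built on a shared core carry different groups on a saturated chain carbon bound to an oxygen on an aromatic ring. Compound 1 `Cc1ccc(NC(=S)NC(=O)c2ccc(OCc3ccccc3F)cc2)cc1-c1nc2ccccc2[nH]1` carries a 2-fluorophenyl there, and in a functional assay on HT-29 cells (Homo sapiens) for inhibition, read by MTT assay, with a stated time of 48 h (a higher number here means a weaker inhibitor, a lower number a stronger inhibitor), compound 1 gives 1870 nM. Compound 2 `Cc1ccc(NC(=S)NC(=O)c2ccc(OCc3cccc(Cl)c3Cl)cc2)cc1-c1nc2ccccc2[nH]1` carries a 2,3-dichlorophenyl and gives 63700 nM; compound 3 `Cc1ccc(NC(=S)NC(=O)c2ccc(OCc3cccc(F)c3)cc2)cc1-c1nc2ccccc2[nH]1` carries a 3-fluorophenyl and gives 55300 nM. Compound 2 stands at the high end of these numbers, close to compound 3 with a 1.2-fold lower number from compound 2 to compound 3 (0.06 log units; within the scatter), and far from compound 1 with a 34-fold higher number from compound 1 to compound 2 (1.53 log units; beyond the scatter).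

Compound 4 `Cc1ccc(NC(=S)NC(=O)c2ccc(OCc3ccc(F)cc3)cc2)cc1-c1nc2ccccc2[nH]1` is the next step: 4-fluorophenyl in place of 2,3-dichlorophenyl on a saturated chain carbon bound to an oxygen on an aromatic ring. For the measured compounds named here, two steps bear on it. Moving a fluorine gave a 30-fold higher number from compound 1 to compound 3 (1.47 log units; beyond the scatter), and replacing the 2-fluorophenyl by the larger group gave a 34-fold higher number from compound 1 to compound 2 (1.53 log units; beyond the scatter), while the two weak compounds sit within scatter of each other. A 4-fluorophenyl resembles the 3-fluorophenyl of compound 3 more than the 2-fluorophenyl of compound 1, so compound 4 is expected to stay near the weak pair, with an expected change of a 1.6-fold lower number from compound 2 to compound 4 (0.20 log units; within the scatter) in this assay. The estimate for compound 4 is therefore 40000 nM, between 8000 nM and 150000 nM.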

Compound 4, half-maximal inhibitory concentration: 1910 nM
Compound 4: middle estimate off by 21-fold (1.32 log units), on the high side, and the stated range ends above it.
By their numbers in this assay, from the lowest: compounds 1 and 4 (each within the scatter of the next); then compounds 3 and 2 (each within the scatter of the next).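

In this assay, the position of one fluorine on the phenyl ring proves decisive, and the change does not run in a simple order around the ring: the 4-fluorophenyl in place of the 3-fluorophenyl gives a 29-fold lower number from compound 3 to compound 4 (1.46 log units; beyond the scatter) and so separates two groups that differ only in where that fluorine sits. The 4-fluorophenyl also stands level with the 2-fluorophenyl, with a 1.0-fold higher number from compound 1 to compound 4 (0.01 log units; within the scatter) and, in place of the 2,3-dichlorophenyl, it gives a 33-fold lower number from compound 2 to compound 4 (1.52 log units; beyond the scatter) so a weak result at this position can be left behind by changing this ring alone. Nothing measured here explains why these fluorine positions differ so sharply.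

On these data alone, whether a plain phenyl would match the 2-fluorophenyl and 4-fluorophenyl compounds or the weak pair remains open. So does the outcome of putting a single chlorine or a methoxy group in place of the fluorine.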